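The source may report more compounds than this note shows. Statements on the series, on what has been measured and on what is new or still open speak of the compounds shown alone.

For the measured compounds named here, the series shares one amide core built around a trifluoromethoxyphenyl piperidine, and only one of its members has so far been put through an ADME assay on Vero cells (Chlorocebus sabaeus) for cytotoxicity, read by CCK-8 assay, with a stated time of 72 h; on this read-out higher numbers stand for weaker inhibition and lower numbers for stronger inhibition. Compound 1 `Cc1ccn2nc(C)c(C(=O)NCc3ccc(N4CCC(c5ccc(OC(F)(F)F)cc5)CC4)cc3)c2c1` was tested, and in this assay compound 1 reached only a limit of the assay, > 100000 nM. Compound 2 `Cc1nn2cccc(C)c2c1C(=O)NCc1ccc(N2CCC(c3ccc(OC(F)(F)F)cc3)CC2)cc1` has no result in this assay, with "not determined" (no result reported) recorded for it. Going by the values given here, compound 3 `Cc1nn2c(C)cccc2c1C(=O)NCc1ccc(N2CCC(c3ccc(OC(F)(F)F)cc3)CC2)cc1` likewise carries no result in this assay, "not determined" (no result reported), so compound 3 stands without a single number among the compounds here, and no step between measured compounds can be drawn. Of the other two entries, one is only a limit of the assay, that of compound 1, and the other has no number at all. The one fixed point is the limit of > 100000 nM in this assay, at which 1 of the 3 values shown sits.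

Compound 4 `COc1ccn2nc(C)c(C(=O)NCc3ccc(N4CCC(c5ccc(OC(F)(F)F)cc5)CC4)cc3)c2c1` differs from compound 3 in that (a group of 12 heavy atoms (9 carbon, 2 nitrogen, 1 oxygen; one five-membered aromatic ring with 2 hetero atoms, one six-membered aromatic ring with 1 hetero atom) in place of a group of 11 heavy atoms (9 carbon, 2 nitrogen; one five-membered aromatic ring with 2 hetero atoms, one six-membered aromatic ring with 1 hetero atom), on a carbonyl carbon). Among the compounds with values here, since no measured step is available, the expectation for compound 4 rests on how closely its shape follows that of compound 1, whose reading in this assay was > 100000 nM; a step of no size beyond the scatter is expected, in no particular direction. Compound 4 is therefore estimated at about 100000 nM in this assay, within a range from 50000 nM to 300000 nM, and most likely it too would be reported only as a limit.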

Compound 4, half-maximal inhibitory concentration: > 100000 nM
Compound 4: no number, only a limit; the forecaster's own chance of this, stated with the estimate: 80%; the middle value lies on the limit itself.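

For the compounds shown here, compound 4, like compound 1, stands only at a limit of the assay in this assay, so no step from compound 1 to compound 4 can be read, in size or in direction: the limit of > 100000 nM in this assay, at which 2 of the 4 values shown sit. The compounds shown leave open where either would fall as an actual number, and whether methoxy in place of methyl changes this read-out at all.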